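Para substituent swap on the shared core: butoxy analogue

This account rests on a few compounds, and the source may have more. Where it says the series, first, only, none or still open, it means among the compounds named here.

Going by the values given here, compound 3 `Cn1c(=O)c2nc(-c3ccc(Br)cc3)[nH]c2n(C)c1=O` gives 0.75 nM in an assay for binding affinity to adenosine receptor A1 (Bos taurus) (a higher number here means a weaker inhibitor, a lower number a stronger inhibitor), the lowest of the three numbers measured so far. Compound 1 `CSc1ccc(-c2nc3c(=O)n(C)c(=O)n(C)c3[nH]2)cc1` gives 2 nM and compound 2 `CN(C)c1ccc(-c2nc3c(=O)n(C)c(=O)n(C)c3[nH]2)cc1` gives 1.8 nM; the step of a 1.1-fold lower number from compound 1 to compound 2 (0.05 log units; within the scatter) lies within the scatter, whereas a 2.7-fold lower number from compound 1 to compound 3 (0.43 log units; beyond the scatter) and a 2.4-fold lower number from compound 2 to compound 3 (0.38 log units; beyond the scatter) are modest but beyond it. Compound 4 `CCCCOc1ccc(-c2nc3c(=O)n(C)c(=O)n(C)c3[nH]2)cc1` carries butoxy in place of bromo on an aromatic carbon. Among the compounds with values here, both measured steps that exchange this same aromatic substituent bear on the change, and each was modest; none of the measured compounds carries a butoxy, so the direction is not settled by the data. Compound 4 is therefore expected to land near compounds 1 and 2, a modest step of a 2.7-fold higher number from compound 3 to compound 4 (0.43 log units; beyond the scatter) towards a higher number. The estimate for compound 4 is 2 nM, with a range from 0.7 nM to 6 nM.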

Compound 4, half-maximal inhibitory concentration: 4 nM
The estimate for compound 4 lay 2.0-fold (0.30 log units) below the measured number; low and high end bracket the measured number.
By their numbers in this assay, from the lowest: compound 3; then compounds 2, 1 and 4 (each within the scatter of the next, the first and the last beyond it).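

In this assay, butoxy on this aromatic carbon gives up the advantage of bromo, with a 5.3-fold higher number from compound 3 to compound 4 (0.73 log units; beyond the scatter). The same change from dimethylamino also stays beyond the scatter, with a 2.2-fold higher number from compound 2 to compound 4 (0.35 log units; beyond the scatter), whereas a 2.0-fold higher number from compound 1 to compound 4 (0.30 log units; within the scatter) lies within it, so the butoxy and methylsulfanyl compounds cannot be separated and only compound 3 stands apart from compound 4. Nothing available explains these steps.

Still open, as far as these compounds go, is how a shorter methoxy or a longer hexyloxy chain would compare at this position. From the compounds shown here alone, a chloro group, a carboxylic acid or a primary amine there also remains open.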